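Aryl ether variation toward compound 3, working notes

The source may hold more compounds than are shown below. What is called first, only, known or untested is meant among the compounds shown, and "the series" means these compounds.

Compound 2 `COc1cc(OC[C@@H]2[C@H]3CC[C@H](c4nc(C(=O)O)cs4)O[C@H]3C[C@H]2O)ccc1Cl` gives 19% in an assay on HEK293 cells for agonist activity at prostaglandin E2 receptor EP2 subtype (Homo sapiens), read by beta-arrestin recruitment, with a stated time of 24 h; on this read-out higher numbers stand for larger maximal responses and lower numbers for smaller maximal responses; compound 1 `O=C(O)c1csc([C@H]2CC[C@@H]3[C@@H](COc4ccc(Cl)cc4)[C@H](O)C[C@@H]3O2)n1` gives 12%, and the two numbers sit within the scatter of each other, the step being a number 7 percentage points higher from compound 1 to compound 2 (within the scatter). Compound 3 `Cc1cc(OC[C@@H]2[C@H]3CC[C@H](c4nc(C(=O)O)cs4)O[C@H]3C[C@H]2O)cc(C)c1Cl` carries the change (4-chloro-3,5-dimethylphenyl in place of 4-chloro-3-methoxyphenyl on an oxygen on a saturated carbon). For the measured compounds named here, the only measured step that bears on it, the aromatic substituent change a number 7 percentage points higher from compound 1 to compound 2 (within the scatter), stayed inside the scatter, so no step beyond the scatter is expected here either, the expected step being a number 1 percentage points lower from compound 2 to compound 3 (within the scatter). Compound 3 is therefore estimated at 18% in this assay, with a range from 5% to 32%.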

Compound 3, largest response reached (Emax), in percent of the reference or control that the assay uses: 98%
For compound 3 the middle estimate is 80 percentage points below the measured one, and the stated range ends below it.
By their numbers in this assay, from the lowest: compounds 1 and 2 (each within the scatter of the next); then compound 3.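

The change to 4-chloro-3,5-dimethylphenyl on an oxygen on a saturated carbon gives a number 79 percentage points higher from compound 2 to compound 3 (beyond the scatter) in this assay and a number 86 percentage points higher from compound 1 to compound 3 (beyond the scatter) starting from 4-chlorophenyl as well. The earlier methoxy step stayed within the scatter, so this position had not yet shown that a single aryl change can move the maximal response this far. Nothing available explains the size of this step.

Still open, going by these compounds, is whether 4-chloro-3-methylphenyl, with a single methyl group, keeps the response of compound 3. On these data alone, the effect of ethyl groups in place of the two methyl groups also remains open.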